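A few compounds are considered here, and "the series" means these few. Any claim that something is new, unique, unknown or untested is made for them only; others in the source may bear on it.

Compound 1 `O=C(Nc1ccc(Cl)cc1CN1C(=O)c2ccccc2C1=O)c1ccccc1[N+](=O)[O-]`: in an assay on CHO cells for positive allosteric modulation of metabotropic glutamate receptor 5 (Rattus norvegicus), read by FLIPR (on this read-out higher numbers stand for an effect only at larger amounts of compound and lower numbers for an effect already at smaller amounts), compound 1 gives < 1000 nM, which is a limit of the assay and not a number.
Compound 2 `O=C(Nc1ccc(Cl)cc1CN1C(=O)c2ccccc2C1=O)c1cccnc1`: compound 2 gives < 1000 nM, again only a limit.
Compound 3 `O=C(Nc1ccc(Cl)cc1CN1C(=O)c2ccccc2C1=O)c1ccco1`: compound 3 gives < 1000 nM, also a limit.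

Compound 3 therefore stands exactly where the other two measured compounds stand, namely at the limit of < 1000 nM in this assay, at which 3 of the 3 values shown sit; no numerical value is known for any of them. The three steps between measured compounds, a step that the two limits leave unreadable from compound 1 to compound 2, a step that the two limits leave unreadable from compound 1 to compound 3 and a step that the two limits leave unreadable from compound 2 to compound 3, are consequently all of unreadable size, and all three concern exchanges of the group on the carbonyl carbon of the shared core.

Compound 4 `O=C(Nc1ccc(Cl)cc1CN1C(=O)c2ccccc2C1=O)c1ccccc1C(F)(F)F` is the next member of the series. It differs from compound 3 by 2-(trifluoromethyl)phenyl in place of furan-2-yl on a carbonyl carbon. Among the compounds with values here, the steps that bear on this change are the three just named, each unreadable, and together they show only that three different groups on that carbonyl carbon all leave the compound past the limit. The author therefore expects compound 4 to fall in the same region, with an expected step that the limit leaves unreadable from compound 3 to compound 4 that cannot be told from no change. Compound 4 is thus estimated at 300 nM in this assay, with a range from 30 nM to 3000 nM.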

Compound 4, half-maximal effective concentration: < 1000 nM
Compound 4: a limit, no number; the forecaster's own chance of this, stated with the estimate: 55%; the middle value lies beyond the limit too.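

Within the data shown here, no step from compound 1, compound 2 or compound 3 to compound 4 can be read, because each value is a limit and not a number: the limit of < 1000 nM in this assay, at which 4 of the 4 values shown sit.
The compounds shown leave open how the four groups on the carbonyl carbon actually compare in this assay.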